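A few compounds are considered here, and "the series" means these few. Any claim that something is new, unique, unknown or untested is made for them only; others in the source may bear on it.

Measured compounds in the series:

compound 1, `Cc1cc(NC(=O)Nc2ccc(C(C)(C)C)cc2)c2ccccc2n1` — 20000 nM
compound 2, `Cc1cc(NC(=O)Nc2cccc(C(N)=O)c2)c2ccccc2n1` — > 25000 nM, a limit
compound 3, `Cc1cc(NC(=O)Nc2ccccc2C(N)=O)c2ccccc2n1` — > 25000 nM, a limit

The read-out is an ADME assay on BJ cells (Homo sapiens) for cytotoxicity, with a stated time of 72 h; a lower number here means that less compound is needed, a higher number that more compound is needed for the effect. Within the data shown here, compound 1 is the one compound of the three that returns a number, giving 20000 nM. Compound 2 returns only a limit, > 25000 nM. Compound 3 likewise returns only a limit, > 25000 nM. Compound 1 therefore stands alone as a quantified value, set against (the limit of > 25000 nM in this assay, at which 2 of the 3 values shown sit), and nothing in this assay can be said about the order of the three compounds among themselves.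

Compound 4, `Cc1cc(NC(=O)Nc2ccc(Cl)cc2)c2ccccc2n1`, is not yet measured. It differs from compound 1 in one place: chloro in place of tert-butyl on an aromatic carbon.

Among the measured compounds shown here, no step between two measured compounds is available to anchor this change. The expectation for compound 4 is that this assay returns no step beyond the scatter, so the expected step is a 1.1-fold higher number from compound 1 to compound 4 (0.04 log units; within the scatter). Compound 4 is estimated at 22000 nM, with a range from 10000 nM to 50000 nM. Compound 4 is expected, with appreciable chance, to return only a limit, as compound 2 and compound 3 do.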

Compound 4, half-maximal effective concentration: > 25000 nM
Compound 4 gave a limit, no number (the forecaster's own chance of this, stated with the estimate: 45%); at least 1.1-fold (0.05 log units) between middle value and limit.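

Among these compounds, this is the first step that can be read at one place: chloro in place of tert-butyl on an aromatic carbon gives, in this assay, an at least 1.2-fold higher number from compound 1 to compound 4 (0.09 log units; that floor lies within the scatter). Compound 4 gives > 25000 nM, which is a limit and not a number, so this change fixes only a floor and not a size. Compound 4 now stands at the same limit as compound 2 and compound 3, leaving a single quantified value among the four: the limit of > 25000 nM in this assay, at which 3 of the 4 values shown sit.

On these data alone, whether an amine, a carboxylic acid or a longer alkyl chain at this place would return a number remains open. As far as these compounds go, the true distance from compound 1 to compound 4 also remains open, with a floor that lies within the scatter and no upper bound.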